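The compounds below may be only part of what the source reports. "The series", "measured", "known", "first", "only" and "open" are said of these compounds alone.

Compound 1 (`Cc1nc(N)c2c(-c3ccccc3)cn([C@@H]3O[C@H](CO)[C@@H](O)[C@H]3O)c2n1`) carries a phenyl group on the shared core. In a functional assay on A549 cells (Homo sapiens), read by MTT assay, with a stated time of 72 h (on this read-out lower numbers stand for stronger inhibition and higher numbers for weaker inhibition), compound 1 gives > 20000 nM, which is a limit of the assay and not a number. Compound 2 (`Cc1nc(N)c2c(-c3cc4ccccc4o3)cn([C@@H]3O[C@H](CO)[C@@H](O)[C@H]3O)c2n1`) has 1-benzofuran-2-yl at the same place. In this assay compound 2 gives > 20000 nM, which is again only a limit. The series therefore stands at the limit of > 20000 nM in this assay, at which 2 of the 2 values shown sit, and compound 2 offers no exact number as a starting point.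

Compound 3 (`C#Cc1cn([C@@H]2O[C@H](CO)[C@@H](O)[C@H]2O)c2nc(C)nc(N)c12`) has ethynyl in place of 1-benzofuran-2-yl on an aromatic carbon. For the measured compounds named here, with a step that the two limits leave unreadable from compound 1 to compound 2 as the only measured step at this place, no measured size can be carried over to the new change. The two measured compounds show nothing about a group as small as ethynyl, so any forecast is loose. In this assay the expected step is an at least 3.3-fold lower number from compound 2 to compound 3 (0.52 log units; beyond the scatter), towards stronger inhibition, though a limit may well be reported again. For compound 3 the estimated value is 6000 nM, with an expected range of 600 nM to 20000 nM.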

Compound 3, half-maximal inhibitory concentration: > 20000 nM
Compound 3: a limit, no number; the forecaster's own chance of this, stated with the estimate: 50%; at least 3.3-fold (0.52 log units) between middle value and limit.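

Compound 3 also gives only a limit and not a number, so its steps from compound 1 and compound 2 cannot be read in this assay. All three compounds now stand at the same point: the limit of > 20000 nM in this assay, at which 3 of the 3 values shown sit.

The compounds shown leave open whether any group at this place on the shared core gives an exact value.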